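The compounds below may be only part of what the source reports. "The series", "measured", "known", "first", "only" and "open" are said of these compounds alone.

Compounds measured in a functional assay on U-937 cells (Homo sapiens) for cytotoxicity, read by MTT assay, with a stated time of 48 h; on this read-out lower numbers stand for stronger inhibition and higher numbers for weaker inhibition:

compound 1 `CCOc1ccc2nc(NC(=S)Nc3ccccc3)sc2c1`: 37700 nM
compound 2 `Fc1ccc2nc(NC(=S)Nc3ccccc3)sc2c1`: reported only as the assay limit > 50000 nM

Compound 2 therefore stands at the limit of > 50000 nM in this assay, at which 1 of the 2 values shown sits, so only a floor for its half-maximal inhibitory concentration is known, not a number. Going by the values given here, compound 1 is the one member of the pair with a measured value, and the single step between the two, an at least 1.3-fold higher number from compound 1 to compound 2 (0.12 log units; that floor lies within the scatter), runs from that number into the limit, so its true size is open.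

Compound 3 `S=C(Nc1ccccc1)Nc1nc2ccccc2s1` is the next member and is yet to be measured in this assay. Relative to compound 2 it differs by hydrogen in place of fluoro on an aromatic carbon. Among the compounds with values here, no measured step removes a fluoro for hydrogen, so the only guide is the position of compound 2 at the limit and the number for compound 1, which both sit at the weak end of the scale. For compound 3 the estimate is a value near the limit again, 50000 nM, with a range from 20000 nM to 150000 nM. The step this implies, a number no higher from compound 2 to compound 3 (the limit leaves the size open), is expected to be small, with a real chance that the assay once more reports only a limit.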

Compound 3, half-maximal inhibitory concentration: > 50000 nM
Compound 3 was reported as a limit (the forecaster's own chance of this, stated with the estimate: 50%); the middle value sits exactly at the limit.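

Hydrogen in place of fluoro on this aromatic carbon does not bring the series off the limit in this assay: compound 2 and compound 3 are both reported only as limits, so the two substituents cannot be told apart here, and the step between them cannot be read. Hydrogen in place of ethoxy gives an at least 1.3-fold higher number from compound 1 to compound 3 (0.12 log units; that floor lies within the scatter), which matches the floor seen for fluoro in place of ethoxy and, lying within the scatter, does not establish that ethoxy has any real edge over either hydrogen or fluoro at this position. The position therefore now carries three substituents but only one number, so the size of any substituent effect stays unresolved: the limit of > 50000 nM in this assay, at which 2 of the 3 values shown sit.

Still open, as far as these compounds go, is whether an amine, a carboxylic acid or a chain longer than ethoxy on this aromatic carbon would give a value clearly clear of the limit in this assay. Also open, from the compounds shown here alone, is whether a change elsewhere in the shared core would do more than any change at this position.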